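The source may report more compounds than this note shows. Statements on the series, on what has been measured and on what is new or still open speak of the compounds shown alone.

Compound 1 `CS(=O)(=O)c1ccc(-c2[nH]c(Br)cc2-c2ccc(F)cc2)cc1` gives 1.05 mg/kg in a functional assay on the whole organism with Rattus norvegicus as the target; a lower number here means that less compound is needed, a higher number that more compound is needed for the effect.
Compound 2 `CS(=O)(=O)c1ccc(-c2[nH]c(Br)c(Br)c2-c2ccc(F)cc2)cc1` gives 1.94 mg/kg in this assay.
Compound 3 `Cc1ccc(S(=O)(=O)n2c(Br)cc(-c3ccc(F)cc3)c2-c2ccc(S(C)(=O)=O)cc2)cc1` gives > 9 mg/kg in this assay, a limit of the assay rather than a number.

Among the two numbers, compound 1 has the lowest, with compound 2 nearest at a 1.8-fold higher number from compound 1 to compound 2 (0.27 log units; within the scatter). For compound 3 the assay reached only its limit, (the limit of > 9 mg/kg in this assay, at which 1 of the 3 values shown sits), so the step of an at least 8.5-fold higher number from compound 1 to compound 3 (0.93 log units; beyond the scatter) is known only as a lower bound. Compound 4 `CS(=O)(=O)c1ccc(-c2[nH]c(F)cc2-c2ccc(F)cc2)cc1` has not been measured. It differs from compound 1 in one place: fluoro in place of bromo on an aromatic carbon. Neither measured step exchanges one halogen for another, so neither bears directly on this change; the nearer one, adding bromo on an aromatic carbon, stayed within the scatter. A step no larger than the scatter is therefore expected in this assay, estimated as a 1.4-fold higher number from compound 1 to compound 4 (0.15 log units; within the scatter). Compound 4 is expected to give about 1.5 mg/kg, between 0.5 mg/kg and 5 mg/kg.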

Compound 4, dose for half-maximal effect: 0.31 mg/kg
Beside the measured number, compound 4's estimate is 4.8-fold (0.68 log units) above it; measured number outside the range, below it.
By their numbers in this assay, from the lowest: compound 4; then compounds 1 and 2 (each within the scatter of the next). At a limit, above all of these: compound 3.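

Putting fluoro in place of bromo at this position, next to the ring nitrogen, gives a 3.4-fold lower number from compound 1 to compound 4 (0.53 log units; beyond the scatter) in this assay. The earlier compounds shown here all carry bromo here, so they could not show that exchanging this halogen alters the dose needed, and this step lies beyond the scatter. Nothing measured here accounts for this change in dose. On these data alone, what chloro, a nitrile or an amine would give at this position stays open. So does the result with plain hydrogen there.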